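A few compounds are considered here, and "the series" means these few. Any claim that something is new, unique, unknown or untested is made for them only; others in the source may bear on it.

Measured compounds, with values in a functional assay on PC-3 cells (Homo sapiens) for antiproliferative activity, read by MTT assay, with a stated time of 48 h; a lower number here means a stronger inhibitor, a higher number a weaker inhibitor:

compound 1, `COc1cc(C(=O)/C=C/c2ccc(OCCCC(=O)NCCCCN(CCCN)CCCCN)cc2)cc(OC)c1OC`: 55400 nM
compound 2, `COc1ccc(/C=C/C(=O)c2cc(OC)c(OC)c(OC)c2)cc1OCCCC(=O)NCCCNCCCCNCCN`: 31800 nM
compound 3, `COc1ccc(/C=C/C(=O)c2cc(OC)c(OC)c(OC)c2)cc1OCCCC(=O)NCCCNCCCCN`: 81000 nM

Compound 1 gives the second highest of the three numbers in this assay. Its nearest neighbour is compound 3, whose number is within the scatter of it, and compound 2 also sits within the scatter of compound 1, so no order among the three can be read from these values.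

Compound 4, `COc1cc(C(=O)/C=C/c2ccc(OCCCC(=O)NCCCCNCCCN)cc2)cc(OC)c1OC`, differs from compound 1 in one place: hydrogen in place of 4-aminobutyl on an amine nitrogen. Among the measured compounds shown here, the only measured step of the same kind is the trimming of the polyamine tail in the other pair, where a 2.5-fold higher number from compound 2 to compound 3 (0.41 log units; beyond the scatter). That step shortened the tail by one aminoalkyl arm and gave a modest move towards a higher number, just beyond the scatter. The change from compound 1 to compound 4 likewise removes one aminoalkyl arm from an amine nitrogen of the tail, so a step of similar size and in the same direction is expected, with the caution that it rests on a single precedent.

For compound 4 the expected step is a 2.0-fold higher number from compound 1 to compound 4 (0.30 log units; within the scatter) in this assay. Compound 4 is therefore estimated at 110000 nM, with a range from 50000 nM to 250000 nM.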

Compound 4, half-maximal inhibitory concentration: 79300 nM
Beside the measured number, compound 4's estimate is 1.4-fold (0.14 log units) above it, within the range that was stated.
By their numbers in this assay, from the lowest: compounds 2, 1, 4 and 3 (each within the scatter of the next, the first and the last beyond it).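

In this assay, among the compounds shown here, hydrogen in place of 4-aminobutyl on the amine nitrogen gives a 1.4-fold higher number from compound 1 to compound 4 (0.16 log units; within the scatter) and so offers the first reading at this position: the arm can be lost from the tail of compound 1 with no readable move in the number. For the compounds shown here, the one earlier step of this kind, a 2.5-fold higher number from compound 2 to compound 3 (0.41 log units; beyond the scatter) for hydrogen in place of 2-aminoethyl, lay beyond the scatter, so loss of an aminoalkyl arm does not give a readable move in every pair, and these two pairs differ in their cores as well as in their tails. Nothing at hand bears on why the step from compound 1 stays within the scatter.

Still open, as far as these compounds go, is whether the arm on this nitrogen matters at all once it is changed rather than removed, for example to a 5-aminopentyl chain, a longer chain, or an arm ending in a carboxylic acid. Going by these compounds alone, also open is whether hydrogen in place of 4-aminobutyl would read the same on the core of compound 2, where the only beyond-scatter step of this kind stands.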